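Swapping Methyl for Chloro: What to Expect

A few compounds are considered here, and "the series" means these few. Any claim that something is new, unique, unknown or untested is made for them only; others in the source may bear on it.

Measured in a functional assay on DU-145 cells (Homo sapiens) for cytotoxicity, read by MTT assay, with a stated time of 72 h; on this read-out lower numbers stand for stronger inhibition of growth and higher numbers for weaker inhibition of growth:
- compound 1 `N#C/C(=C/c1ccc2ccccc2c1)C(=O)c1ccc[nH]1` gives < 10000 nM, a limit
- compound 2 `Cc1ccc(/C=C(/C#N)C(=O)c2ccc[nH]2)cc1` gives < 10000 nM, a limit

Neither compound has an exact number here. Compound 2 stands at < 10000 nM, which is a limit and not a measured point. The same holds for both compounds, as the limit of < 10000 nM in this assay, at which 2 of the 2 values shown sit, shows, so no order between them can be read from this assay.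

The next compound is compound 3 `N#C/C(=C/c1ccc(Cl)cc1)C(=O)c1ccc[nH]1`. It keeps the shared core of compound 2 and carries chloro in place of methyl on an aromatic carbon, para to a large group (chloro in place of methyl on an aromatic carbon).

For the measured compounds named here, no measured pair here shows what such a swap does. The expectation therefore starts from compound 2, whose result of < 10000 nM is only a limit. No change beyond the usual scatter is expected, and no direction is favoured. The estimated change is a step that the limit leaves unreadable from compound 2 to compound 3. For compound 3 the expected value is 4000 nM, with an estimated range from 800 nM to 10000 nM.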

Compound 3, concentration for 50% growth inhibition: 32000 nM
Compound 3: the middle estimate sits 8.0-fold (0.90 log units) below what was measured, and the stated range ends below it.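

In this assay, putting chloro in place of methyl on an aromatic carbon, para to a large group, gives an at least 3.2-fold higher number from compound 2 to compound 3 (0.50 log units; beyond the scatter). For the compounds shown here, this is the first exact number, with compound 3 at 32000 nM, and it shows that this swap at this position is not neutral: the chloro compound shows a clearly higher number, so it inhibits growth more weakly than the methyl compound. The true size of the step remains unknown and could be larger than the printed figure, because compound 2 is known only through a limit: the limit of < 10000 nM in this assay, at which 2 of the 3 values shown sit.

The compounds shown leave open how large the gap between methyl and chloro really is, which only an exact number for compound 2 could settle, and they give no reason for the weaker result with chloro. They also leave open whether other groups at the same place, such as fluoro, methoxy or an amine, would fall closer to methyl or to chloro in this read-out.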